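Ethylsulfanyl Replaced by Pentan-3-yloxy on the Carbonyl Carbon

The compounds below may be only part of what the source reports. "The series", "measured", "known", "first", "only" and "open" are said of these compounds alone.

Of the compounds shown here, two that share one core have been tested in an assay on membranes from CHO cells for displacement of a labelled ligand from adenosine receptor A1 (Homo sapiens), read by scintillation counting, with a stated time of 60 min, tested at 1 uM; a lower number here means less inhibition, a higher number more inhibition at the concentration tested (going by the name of the read-out). Compound 1, `CC1=C(C(=O)C2CC2)C(c2ccco2)NC(=O)N1`, gives 2%. Compound 2, `CCSC(=O)C1=C(C)NC(=O)NC1c1ccco1`, gives 6%. Among the compounds with values here, the only change between them is ethylsulfanyl in place of cyclopropyl on a carbonyl carbon, and the step of a number 4 percentage points higher from compound 1 to compound 2 (within the scatter) lies within the scatter, so the two numbers cannot be told apart. Within the data shown here, compound 2 therefore stands among small numbers, with compound 1 its only neighbour and the gap between them within the scatter.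

Compound 3, `CCC(CC)OC(=O)C1=C(C)NC(=O)NC1c1ccco1`, has not yet been measured. It differs from compound 2 in one place: (pentan-3-yl)oxy in place of ethylsulfanyl on a carbonyl carbon. Among the measured compounds shown here, no measured step introduces an oxygen-linked chain on this carbonyl carbon; the only step at the same position is a number 4 percentage points higher from compound 1 to compound 2 (within the scatter), and it was small. Both measured compounds show little inhibition, and one change at this carbonyl carbon left the number within the scatter. Compound 3 is therefore expected to stay in the same low region, with the step of a number 1 percentage points lower from compound 2 to compound 3 (within the scatter) expected to be none beyond the scatter. The estimate for compound 3 in this assay is 5%, within a range from 0% to 15%.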

Compound 3, a percentage reported as inhibition, at one concentration (the size of the read-out at that concentration, not a potency): 2%
Compound 3: the middle estimate sits 3 percentage points above what was measured; low and high end bracket the measured number.
By their numbers in this assay, from the lowest: compounds 1, 3 and 2 (each within the scatter of the next).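

In this assay the change to (pentan-3-yl)oxy on the carbonyl carbon gives a number 4 percentage points lower from compound 2 to compound 3 (within the scatter) when it replaces ethylsulfanyl and no change at the digits printed from compound 1 to compound 3 (within the scatter) when it replaces cyclopropyl on that carbon. The earlier pair held no oxygen-linked group at this position; this one brings an oxygen link and 6 heavy atoms against the 3 of ethylsulfanyl, yet the three compounds remain together at small numbers and cannot be told apart. So, among these three groups, neither the linking atom nor the size of the group separates the compounds in this assay, and no other measurement is at hand to explain these numbers.

All three groups shown on this carbon give small numbers at the single concentration tested, so it remains open whether a group of another kind there, such as an amine or a carboxylic acid, would give a number beyond the scatter. Also open, from the compounds shown here alone, is whether a longer chain on the oxygen, or a change elsewhere on the shared core, would lift the number out of this low region.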